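A Methylsulfonyl Swap at the Cyano Position

A few compounds are considered here, and "the series" means these few. Any claim that something is new, unique, unknown or untested is made for them only; others in the source may bear on it.

Measured so far in a functional assay on MDA-MB-231 cells (Homo sapiens) for cytotoxicity, with a stated time of 48 h; on this read-out higher numbers stand for weaker inhibition and lower numbers for stronger inhibition:
compound 1 `Oc1ccc(-c2cncc(-c3cc4ccc(O)cc4[nH]3)n2)cc1` gives 10000 nM
compound 2 `N#Cc1ccc(-c2cncc(-c3cc4ccc(O)cc4[nH]3)n2)cc1` gives 6000 nM

Going by the values given here, with only two compounds measured, compound 2 stands level with compound 1 once the usual scatter is allowed for. Among the compounds with values here, the single measured comparison, a 1.7-fold lower number from compound 1 to compound 2 (0.22 log units; within the scatter), separates them by no more than that scatter.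

The next compound is compound 3 `CS(=O)(=O)c1ccc(-c2cncc(-c3cc4ccc(O)cc4[nH]3)n2)cc1`. It keeps the shared core of compound 2 and carries methylsulfonyl in place of cyano on an aromatic carbon, at the same place, para to a large group.

Within the data shown here, only one measured step bears on this change, since it is the one exchange made at that place. As that step stayed within the scatter, no step beyond the scatter is expected in this assay, in either direction, though a single step is thin evidence. The expected step is no change at the digits printed from compound 2 to compound 3 (within the scatter) and the estimate starts from compound 2 at 6000 nM as its anchor.

The estimated value for compound 3 is 6000 nM, with an expected range from 2500 nM to 14000 nM around it.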

Compound 3, half-maximal inhibitory concentration: 9000 nM
The estimate for compound 3 lay 1.5-fold (0.18 log units) below the measured number; the range from low to high includes it.
By their numbers in this assay, from the lowest: compounds 2, 3 and 1 (each within the scatter of the next).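

In this assay, the place on the aromatic carbon para to a large group now carries three different groups, and the exchange of cyano for methylsulfonyl gives a 1.5-fold higher number from compound 2 to compound 3 (0.18 log units; within the scatter), while the exchange of hydroxy for methylsulfonyl gives a 1.1-fold lower number from compound 1 to compound 3 (0.05 log units; within the scatter). Where the earlier compounds offered one comparison at this place, there are now three, and none of them separates its pair; even cyano and methylsulfonyl, which differ in their counts of heavy atoms and hydrogen-bond acceptors, stand level in this read-out. Nothing available here accounts for this levelness, so it stands as an observation on these three compounds alone.

From the compounds shown here alone, whether any group at this place can move the number beyond the scatter remains open, and an amine, a carboxylic acid or a longer alkyl chain there would be a further test of it. All three compounds share the same core, so they also leave open how the number would respond to a change anywhere else on it, such as replacing either of its hydroxy groups with a methoxy group.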